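Aryl Swap on a Triazole Amide: Weak Inhibitors Throughout

The source may report more compounds than this note shows. Statements on the series, on what has been measured and on what is new or still open speak of the compounds shown alone.

Measured compounds:
- compound 1, `Cc1ccc(-n2cc(CNC(=O)c3cccc4c3cnn4C(C)C)nn2)cc1C`: 23400 nM
- compound 2, `Cc1cccc(-n2cc(CNC(=O)c3cccc4c3cnn4C(C)C)nn2)c1`: 32300 nM
- compound 3, `Cc1ccccc1-n1cc(CNC(=O)c2cccc3c2cnn3C(C)C)nn1`: 19200 nM

In a functional assay on PC-3 cells (Homo sapiens) for inhibition, read by MTT assay, with a stated time of 72 h (a lower number here means a stronger inhibitor, a higher number a weaker inhibitor), compound 1 gives 23400 nM, which places it second highest of the three numbers; the three compounds all fall within the usual scatter of one another, so none can be called stronger or weaker than the rest. The steps among them confirm this: a 1.4-fold higher number from compound 1 to compound 2 (0.14 log units; within the scatter), a 1.2-fold lower number from compound 1 to compound 3 (0.09 log units; within the scatter) and a 1.7-fold lower number from compound 2 to compound 3 (0.23 log units; within the scatter) all stay within the scatter, even though each step moves or removes a methyl on the phenyl ring attached to the shared core.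

Compound 4, `CCc1ccc(-n2cc(CNC(=O)c3cccc4c3cnn4C(C)C)nn2)cc1`, has not yet been measured. Compared with compound 1 the difference is 4-ethylphenyl in place of 3,4-dimethylphenyl on an aromatic nitrogen. The three measured steps are the ones that bear on it, since all of them also change only the pattern of small alkyl groups on this phenyl ring, and none of them moved the number beyond the scatter. A step of similar size in this assay is therefore expected, with no clear direction, so compound 4 is expected to give about 25000 nM with a range from 12000 nM to 50000 nM. This corresponds to an expected step of a 1.1-fold higher number from compound 1 to compound 4 (0.03 log units; within the scatter).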

Compound 4, half-maximal inhibitory concentration: 26600 nM
The estimate for compound 4 lay 1.1-fold (0.03 log units) below the measured number; the range from low to high includes it.
By their numbers in this assay, from the lowest: compounds 3, 1, 4 and 2 (each within the scatter of the next).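

Compound 4 brings a different kind of alkyl group to this place on the aromatic nitrogen: one ethyl chain instead of separate methyl groups, with the aryl group still at 8 heavy atoms. In this assay that change also leaves the number without a readable shift (a 1.1-fold higher number from compound 1 to compound 4 (0.06 log units; within the scatter)), and the same holds against the two single-methyl compounds (a 1.4-fold higher number from compound 3 to compound 4 (0.14 log units; within the scatter) and a 1.2-fold lower number from compound 2 to compound 4 (0.08 log units; within the scatter)). Across these four compounds, then, neither the placing of small alkyl groups on the phenyl ring nor joining the carbons into an ethyl chain separates one compound from another, and nothing available here accounts for this flat result.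

As far as these compounds go, what remains open is whether a group of another kind on this phenyl ring, such as an amine or a carboxylic acid, would move the number beyond the scatter. The compounds shown also cannot tell whether a longer chain, as in 4-butylphenyl, would do so.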